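Bromo in Place of Fluoro on Compound 2

The source may hold more compounds than are shown below. What is called first, only, known or untested is meant among the compounds shown, and "the series" means these compounds.

For the measured compounds named here, compound 2 `Fc1ccc(C2=NN(C3=NC(c4ccccc4)CS3)C(c3cccc4ccccc34)C2)cc1` stands at the high end of the three numbers so far recorded in a functional assay on HeLa cells (Homo sapiens) for inhibition, read by CCK-8 assay, with a stated time of 48 h; a lower number here means a stronger inhibitor, a higher number a weaker inhibitor: compound 2 gives 12400 nM. Compound 1 `c1ccc(C2=NN(C3=NC(c4ccccc4)CS3)C(c3cccc4ccccc34)C2)cc1` carries hydrogen where compound 2 carries fluoro; compound 1 gives 5320 nM in this assay, and the step of a 2.3-fold higher number from compound 1 to compound 2 (0.37 log units; beyond the scatter). Compound 3 `Fc1ccc(C2=NN(C3=NC(c4ccccc4)CS3)C(c3ccc4ccccc4c3)C2)cc1`, with naphthalen-2-yl in place of naphthalen-1-yl on a saturated ring carbon, gives 9730 nM, and the step of a 1.3-fold lower number from compound 2 to compound 3 (0.11 log units; within the scatter).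

Compound 4 `Brc1ccc(C2=NN(C3=NC(c4ccccc4)CS3)C(c3cccc4ccccc34)C2)cc1` is not yet measured. It differs from compound 2 in one place: bromo in place of fluoro on an aromatic carbon. Going by the values given here, no measured step exchanges one halogen for another. Among the compounds with values here, the only step that touches this aromatic carbon is a 2.3-fold higher number from compound 1 to compound 2 (0.37 log units; beyond the scatter), which is modest and runs toward a higher number. The step of a 1.3-fold lower number from compound 2 to compound 3 (0.11 log units; within the scatter) concerns a different part of the molecule and does not bear on the exchange. With so little to go on, compound 4 is expected to land near the number of its parent rather than far from it. For compound 4 the expected step is a 1.2-fold lower number from compound 2 to compound 4 (0.09 log units; within the scatter), which would not reach beyond the scatter. The estimate for compound 4 is 10000 nM, with a range from 4000 nM to 25000 nM.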

Compound 4, half-maximal inhibitory concentration: 6650 nM
Beside the measured number, compound 4's estimate is 1.5-fold (0.18 log units) above it, within the range that was stated.
By their numbers in this assay, from the lowest: compounds 1, 4, 3 and 2 (each within the scatter of the next, the first and the last beyond it).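

In this assay, for the compounds shown here, this is the first exchange of one halogen for another on this aromatic carbon, 4-fluorophenyl to 4-bromophenyl (a 1.9-fold lower number from compound 2 to compound 4 (0.27 log units; within the scatter)), and it leaves compound 2 and compound 4 within the scatter of each other. The earlier compounds shown here showed only that fluoro in place of hydrogen gave a step beyond the scatter (a 2.3-fold higher number from compound 1 to compound 2 (0.37 log units; beyond the scatter)), whereas bromo in place of hydrogen on the same carbon does not (a 1.3-fold higher number from compound 1 to compound 4 (0.10 log units; within the scatter)), so compound 4 cannot be separated from either compound 1 or compound 2 and the position does not yet show a clear effect of halogen identity. No measurement available here explains the numbers at this position.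

The compounds shown leave open how chloro, methoxy, an amine or a carboxylic acid on this aromatic carbon would read in this assay, and so whether any group there can move the number well beyond the scatter. They also leave open whether bromo would read the same alongside the naphthalen-2-yl group of compound 3 as it does alongside the naphthalen-1-yl group of compound 4.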